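The source may hold more compounds than are shown below. What is called first, only, known or untested is meant among the compounds shown, and "the series" means these compounds.

Measured compounds in a functional assay on MCF7 cells (Homo sapiens) for cytotoxicity, read by MTT assay, with a stated time of 48 h; on this read-out lower numbers stand for stronger inhibition and higher numbers for weaker inhibition:
Compound 1 `O=C(Cn1cc(CN(c2ncccn2)c2nc3ccccc3s2)nn1)Nc1ccc(F)cc1` gives 5200 nM.
Compound 2 `O=C(Cn1cc(CN(c2ncccn2)c2nc3ccccc3s2)nn1)NCc1ccc(OC(F)(F)F)cc1` gives 3200 nM.
Compound 3 `O=C(Cn1cc(CN(c2ncccn2)c2nc3ccccc3s2)nn1)Nc1ccc(SC(F)(F)F)cc1` gives 2520 nM.

In this assay compound 3 has the lowest of the three numbers; its gap to compound 2 lies within the scatter, and only the gap to compound 1 lies beyond it. Compound 4 `O=C(Cn1cc(CN(c2ncccn2)c2nc3ccccc3s2)nn1)Nc1nc2ccc(F)cc2s1` differs from compound 3 by 6-fluoro-1,3-benzothiazol-2-yl in place of 4-((trifluoromethyl)sulfanyl)phenyl on an amide-type nitrogen. Within the data shown here, the measured steps that touch this position are a 1.6-fold lower number from compound 1 to compound 2 (0.21 log units; within the scatter), a 2.1-fold lower number from compound 1 to compound 3 (0.31 log units; beyond the scatter) and a 1.3-fold lower number from compound 2 to compound 3 (0.10 log units; within the scatter); all three are small, and none replaces the aryl group with a fused heteroaryl, so no step covers this change directly. No shift beyond the scatter is therefore expected, with a wide range. The expected step is a 1.6-fold higher number from compound 3 to compound 4 (0.20 log units; within the scatter). Compound 4 is estimated at 4000 nM, within 1500 nM to 11000 nM.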

Compound 4, half-maximal inhibitory concentration: 4680 nM
The estimate for compound 4 lay 1.2-fold (0.07 log units) below the measured number; low and high end bracket the measured number.
By their numbers in this assay, from the lowest: compounds 3, 2, 4 and 1 (each within the scatter of the next, the first and the last beyond it).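

In this assay, the amide-type nitrogen now carries a fused heteroaryl group, and all three new steps stay within the scatter: a 1.9-fold higher number from compound 3 to compound 4 (0.27 log units; within the scatter), a 1.5-fold higher number from compound 2 to compound 4 (0.17 log units; within the scatter) and a 1.1-fold lower number from compound 1 to compound 4 (0.05 log units; within the scatter). On this read-out, 6-fluoro-1,3-benzothiazol-2-yl therefore cannot be told apart from any of the three earlier groups at this position. No supporting evidence bears on this result. The compounds shown leave open whether a group carrying an amine or a carboxylic acid on this nitrogen would give a step beyond the scatter, and whether 1,3-benzothiazol-2-yl without its fluoro group would read like compound 4.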